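Swapping the ester tail of a cyclopentenone for a hydroxyethyl group

The source may hold more compounds than are shown below. What is called first, only, known or untested is meant among the compounds shown, and "the series" means these compounds.

Measured so far:
- compound 1, `CC/C=C\C[C@H]1C(=O)C=C[C@H]1CC(=O)OCCCC`: 23000 nM
- compound 2, `CC/C=C\C[C@H]1C(=O)C=C[C@H]1CC(=O)Oc1ccccc1OC`: 32000 nM

Both compounds share a cyclopentenone core carrying an unsaturated side chain and an ester. In a functional assay on RAW264.7 cells (Mus musculus) for inhibition, read by ELISA, with a stated time of 24 h (a higher number here means that more compound is needed for the effect, a lower number that less compound is needed), compound 1 gives 23000 nM, and compound 2, whose ester bears a methoxy-substituted aryl group instead of a butyl chain, gives 32000 nM. Compound 1 has the lower of the two numbers, but the gap to compound 2 falls within the usual scatter of repeated measurements, so neither compound can be called more active than the other on this evidence.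

The unmeasured compound 3, `CC/C=C\C[C@H]1C(=O)C=C[C@H]1CC(=O)OCCO`, keeps the core of compound 1 and alters only the ester chain: hydroxy in place of ethyl on a saturated chain carbon, two bonds along the chain from an oxygen next to a carbonyl group.

For the measured compounds named here, no pair measured here isolates a change of this kind, so there is no direct precedent to draw on. The two measured values sit close together despite a large change of the ester group, which suggests that the ester tail is not a strong lever in this assay. A step from compound 1 to compound 3 that stays within the scatter, or at most a small move toward a higher number, is therefore expected, a 1.5-fold higher number from compound 1 to compound 3 (0.18 log units; within the scatter). For compound 3 the estimated value in this assay is 35000 nM, with a plausible range from 12000 nM to 100000 nM.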

Compound 3, half-maximal effective concentration: 24000 nM
Compound 3: the middle estimate sits 1.5-fold (0.16 log units) above what was measured; the measured number falls inside the stated range.
By their numbers in this assay, from the lowest: compounds 1, 3 and 2 (each within the scatter of the next).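

In this assay, hydroxy in place of ethyl, which turns the butyl of compound 1 into the 2-hydroxyethyl of compound 3, gives a 1.0-fold higher number from compound 1 to compound 3 (0.02 log units; within the scatter) and so leaves the two numbers within the scatter of each other. For the compounds shown here, until now no measured step isolated a single place on the ester chain; this one does, and on a saturated chain carbon, two bonds along the chain from an oxygen next to a carbonyl group, adding a hydrogen-bond donor and a hydrogen-bond acceptor to a chain end that had neither produces no difference that can be told from scatter. No available measurement bears on why the two numbers stand so close.

As far as these compounds go, whether an amine or a carboxylic acid at this place, or a longer chain ending in hydroxy, would give a number beyond the scatter remains open. From the compounds shown here alone, all three numbers also come from this assay alone, so how far this result holds for the same compounds in any other test is unknown.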